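From hydroxymethyl to isopropyl on a shared core

The source may hold more compounds than are shown below. What is called first, only, known or untested is meant among the compounds shown, and "the series" means these compounds.

Measured in an ADME assay on KB cells (Homo sapiens) for cytotoxicity, with a stated time of 48 h; a lower number here means a stronger inhibitor, a higher number a weaker inhibitor:
- compound 1 `C=C1[C@H](C)CCC[C@]1(C)CC/C(C)=C/CC1=C(O)C(=O)C=C(N[C@@H](C(=O)O)[C@H](C)O)C1=O`: > 10 ug/mL, a limit
- compound 2 `C=C1[C@H](C)CCC[C@]1(C)CC/C(C)=C/CC1=C(O)C(=O)C=C(NCC(=O)O)C1=O`: 4 ug/mL
- compound 3 `C=C1[C@H](C)CCC[C@]1(C)CC/C(C)=C/CC1=C(O)C(=O)C=C(N[C@@H](CO)C(=O)O)C1=O`: > 10 ug/mL, a limit

Compound 3 has a limit and no number, and this is the limit of > 10 ug/mL in this assay, at which 2 of the 3 values shown sit. Compound 4 `C=C1[C@H](C)CCC[C@]1(C)CC/C(C)=C/CC1=C(O)C(=O)C=C(N[C@H](C(=O)O)C(C)C)C1=O` is still unmeasured. It carries isopropyl in place of hydroxymethyl on a saturated chain carbon bound to an amine nitrogen and a carbonyl carbon.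

Among the measured compounds shown here, three measured steps bear on this change. The first is an at least 2.5-fold higher number from compound 2 to compound 3 (0.39 log units; beyond the scatter), and the second is an at least 2.5-fold lower number from compound 1 to compound 2 (0.39 log units; beyond the scatter). Both show that compound 2, with only hydrogen on that carbon, gives the lower number. The third, a step that the two limits leave unreadable from compound 1 to compound 3, adds nothing on size. Isopropyl itself is untested here, and it holds no oxygen, unlike the groups in compound 1 and compound 3. A modest fall from the limit is therefore expected, though compound 4 may well stay at the limit. The expected change is an at least 1.6-fold lower number from compound 3 to compound 4 (0.22 log units; that floor lies within the scatter). For compound 4 the estimate is 6 ug/mL, with an expected range from 2 ug/mL to 15 ug/mL.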

Compound 4, half-maximal inhibitory concentration: > 10 ug/mL
Compound 4: only a limit was reported; the forecaster's own chance of this, stated with the estimate: 35%; at least 1.6-fold (0.22 log units) between middle value and limit.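

Compound 4, with isopropyl on the saturated chain carbon bound to an amine nitrogen and a carbonyl carbon, gives > 10 ug/mL in this assay, which is a limit. Placing isopropyl instead of hydrogen on that carbon gives an at least 2.5-fold higher number from compound 2 to compound 4 (0.39 log units; beyond the scatter), so the lower number with hydrogen now holds against a group without oxygen as well as against the two groups that carry it. The steps joining compound 1, compound 3 and compound 4 cannot be read, and the limit is now shared more widely: the limit of > 10 ug/mL in this assay, at which 3 of the 4 values shown sit.

On these data alone, how far compound 1, compound 3 and compound 4 lie from one another stays open, so no order can be given among their groups. Also open, as far as these compounds go, is whether methyl, or a chain ending in an amine or a second carboxylic acid, on that carbon would keep the value of compound 2 or lose it.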